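Nitro in place of methoxy on the central ring: compound 4

This account rests on a few compounds, and the source may have more. Where it says the series, first, only, none or still open, it means among the compounds named here.

Measured so far:
Compound 1 `Fc1ccc2nc(-c3cccc(-c4nc5ccc(F)cc5[nH]4)c3)[nH]c2c1` — in a functional assay on MCF7 cells (Homo sapiens) for cytotoxicity, read by MTT assay, with a stated time of 48 h (on this read-out lower numbers stand for stronger inhibition and higher numbers for weaker inhibition), compound 1 gives > 100000 nM, which is a limit of the assay and not a number.
Compound 2 `FC(F)(F)c1ccc2nc(-c3cccc(-c4nc5ccc(C(F)(F)F)cc5[nH]4)c3)[nH]c2c1` — in this assay compound 2 gives 12800 nM.
Compound 3 `COc1cc(-c2nc3ccc(C(F)(F)F)cc3[nH]2)cc(-c2nc3ccc(C(F)(F)F)cc3[nH]2)c1` — in this assay compound 3 gives 11900 nM.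

Among the measured compounds shown here, compound 3 carries one of only two numbers; the other belongs to compound 2, and the step of a 1.1-fold lower number from compound 2 to compound 3 (0.03 log units; within the scatter) is within the scatter, so the two are not told apart. Compound 1 sits at the limit of > 100000 nM in this assay, at which 1 of the 3 values shown sits.

Compound 4 `O=[N+]([O-])c1cc(-c2nc3ccc(C(F)(F)F)cc3[nH]2)cc(-c2nc3ccc(C(F)(F)F)cc3[nH]2)c1` differs from compound 3 by nitro in place of methoxy on an aromatic carbon, at the position meta to two large groups. For the measured compounds named here, the single measured step at this position, a 1.1-fold lower number from compound 2 to compound 3 (0.03 log units; within the scatter), was within the scatter. Going by the values given here, no measured compound carries a nitro, so no step bears on the change directly; the only guidance is that substitution at this carbon left the number unmoved once.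

The expectation is therefore a step of no size beyond the scatter: compound 4 is estimated at 12000 nM in this assay, with a range from 4000 nM to 40000 nM, the expected step being a 1.0-fold higher number from compound 3 to compound 4 (0.00 log units; within the scatter).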

Compound 4, half-maximal inhibitory concentration: 9400 nM
Compound 4: middle estimate off by 1.3-fold (0.11 log units), on the high side; measured number inside the range.
By their numbers in this assay, from the lowest: compounds 4, 3 and 2 (each within the scatter of the next). At a limit, above all of these: compound 1.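

In this assay, among the compounds shown here, the aromatic carbon meta to two large groups takes nitro in place of methoxy with a 1.3-fold lower number from compound 3 to compound 4 (0.10 log units; within the scatter), so a second substituent at this carbon also fails to separate from the earlier compounds. Against hydrogen at the same carbon, nitro gives a 1.4-fold lower number from compound 2 to compound 4 (0.13 log units; within the scatter), and hydrogen, methoxy and nitro at this position are therefore not told apart in this assay. No measurement of any property of these groups bears on this result.

On these data alone, whether an amine or a carboxylic acid at this carbon would also stay within the scatter of compound 2 remains open. Also open, as far as these compounds go, is how substitution at this carbon reads out with fluoro in place of trifluoromethyl, as in compound 1, whose > 100000 nM is a limit of the assay and not a number.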